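Thiourea to propylurea on the aminophenyl alcohol core

The compounds below may be only part of what the source reports. "The series", "measured", "known", "first", "only" and "open" are said of these compounds alone.

Compound 3 `CNC(=S)NCCC(O)c1ccccc1N` is measured in an assay for inhibition of Nitric oxide synthase, inducible (Homo sapiens), read by scintillation counting, with a stated time of 30 min, tested at 1 mM (on this read-out higher numbers stand for more inhibition at the one concentration tested (going by the name of the read-out) and lower numbers for less inhibition), at 20.7%. Compound 2 `COc1ccc(N)c(C(=O)CCNC(=O)c2ccccc2)c1` gives 10.9% in this assay, within the scatter of compound 3, while compound 1 `COc1ccc(N)c(C(=O)CCNC(=O)C2CC2)c1` gives 2.66%, beyond it. Compound 4 `CCCNC(=O)NCCC(O)c1ccccc1N` differs from compound 3 in one place: a group of 6 heavy atoms (4 carbon, 1 nitrogen, 1 oxygen; no ring) in place of a group of 4 heavy atoms (2 carbon, 1 nitrogen, 1 sulfur; no ring), on an amine nitrogen. Within the data shown here, the only measured step, a change of one group on a carbonyl carbon, ran a number 8.2 percentage points higher from compound 1 to compound 2 (within the scatter) and stayed within the scatter. Nothing measured exchanges a sulfur-bearing group for an oxygen-bearing one on an amine nitrogen, so the step to compound 4 is expected to stay within the scatter, a number 4.7 percentage points lower from compound 3 to compound 4 (within the scatter). Compound 4 is therefore estimated at 16%, between 2% and 34%.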

Compound 4, a percentage reported as inhibition, at one concentration (the size of the read-out at that concentration, not a potency): 19%
Beside the measured number, compound 4's estimate is 3 percentage points below it, within the range that was stated.
By their numbers in this assay, from the lowest: compounds 1, 2, 4 and 3 (each within the scatter of the next, the first and the last beyond it).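

Propylcarbamoyl in place of the sulfur-bearing group on an amine nitrogen gives a number 1.7 percentage points lower from compound 3 to compound 4 (within the scatter) in this assay, a reading at a place that the earlier step, on a carbonyl carbon, did not touch. At this position, then, the larger group with oxygen leaves the read-out within the scatter. Nothing measured here accounts for this result. Going by these compounds, the step exchanges sulfur for oxygen and changes the chain at once, so the share of each stays open. On these data alone, what a longer chain or a carboxylic acid on this amine nitrogen would give also stays open.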